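Chloro on the phenyl ring of the 5-HT7 arylpiperazine series

A few compounds are considered here, and "the series" means these few. Any claim that something is new, unique, unknown or untested is made for them only; others in the source may bear on it.

Of the compounds shown here, two have been measured in an assay on cell membranes (strain Wistar) for displacement of a labelled ligand from 5-hydroxytryptamine receptor 7 (Rattus norvegicus); a higher number here means a weaker inhibitor, a lower number a stronger inhibitor. Compound 1, `CCOc1nc2c(c(=O)n(C)c(=O)n2C)n1CCCCN1CCN(c2ccccc2)CC1`, gives 197 nM in this assay. For the measured compounds named here, compound 2, `Cn1c(=O)c2c([nH]c(=O)n2CCCCN2CCN(c3ccccc3)CC2)n(C)c1=O`, gives 1820 nM in this assay, the highest of the two numbers; the only neighbour is compound 1, whose number is lower by a margin beyond the usual scatter. Compound 3, `Cn1c(=O)c2c([nH]c(=O)n2CCCCN2CCN(c3cccc(Cl)c3)CC2)n(C)c1=O`, has not yet been measured in this assay. It differs from compound 2 in one place: chloro in place of hydrogen on an aromatic carbon — chloro in place of hydrogen on an aromatic carbon, meta to a large group, so that the phenyl becomes a 3-chlorophenyl. Going by the values given here, no measured pair shows the effect of this change, so the direction and size of the step rest on expectation alone. A small lowering of the inhibition constant is expected, since such a change on the phenylpiperazine end of these compounds usually moves the number by less than the margin seen between compound 1 and compound 2. The expected step from compound 2 to compound 3 is a 2.0-fold lower number from compound 2 to compound 3 (0.31 log units; beyond the scatter). For compound 3 in this assay the estimated value is 900 nM, within a range from 300 nM to 2700 nM.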

Compound 3, inhibition constant: 3670 nM
For compound 3 the middle estimate is 4.1-fold (0.61 log units) below the measured one; measured number outside the range, above it.
By their numbers in this assay, from the lowest: compound 1; then compounds 2 and 3 (each within the scatter of the next).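

In this assay, for the compounds shown here, the one pair differing in a single place gives a 2.0-fold higher number from compound 2 to compound 3 (0.30 log units; within the scatter), so replacing phenyl with 3-chlorophenyl does not separate compound 3 from compound 2 beyond the usual scatter. Going by these compounds alone, this is the first direct reading of the change at this position, and it shows no gain from chloro on an aromatic carbon, meta to a large group, on this core; as a single pair, it sets no rule for the wider series. Nothing available bears on the reason for this result.

Still open, on these data alone, is whether the same chloro would behave alike on the core of compound 1, and whether fluoro, methoxy or trifluoromethyl at this place, or chloro on another carbon of the ring, would give a step beyond the scatter. Also open, as far as these compounds go, is whether a longer chain in place of the present linker would alter the reading for compound 2 and compound 3 in this assay, or leave these two compounds unresolved from each other.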